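A few compounds are considered here, and "the series" means these few. Any claim that something is new, unique, unknown or untested is made for them only; others in the source may bear on it.

Series notes. Compound 1 `COc1cc2c(Oc3ccc(NC(=O)c4cc(-c5ccccc5)nc5ccccc45)cc3F)ccnc2cc1OCCCN1CCCCC1` gives 15 nM in a functional assay on MKN-45 cells (Homo sapiens) for cytotoxicity, read by MTT assay, with a stated time of 72 h; on this read-out lower numbers stand for stronger inhibition and higher numbers for weaker inhibition. Compound 2 `COc1cc2c(Oc3ccc(NC(=O)c4cc(-c5ccc(F)cc5)nc5ccccc45)cc3F)ccnc2cc1OCCCN1CCCCC1` gives 28 nM; it differs from compound 1 by fluoro in place of hydrogen on an aromatic carbon, and the step is a 1.9-fold higher number from compound 1 to compound 2 (0.27 log units; within the scatter). Compound 3 `COc1cc2c(Oc3ccc(NC(=O)c4cc(-c5cccc(Cl)c5)nc5ccccc45)cc3F)ccnc2cc1OCCCN1CCC(C)CC1` gives 30 nM; the difference between the core of compound 1 and the core of compound 3 is not broken down here. Compound 4 `COc1cc2c(Oc3ccc(NC(=O)c4cc(-c5cccc(Cl)c5)nc5ccc(F)cc45)cc3F)ccnc2cc1OCCCN1CCC(C)CC1` is not yet measured in this assay. It differs from compound 3 by fluoro in place of hydrogen on an aromatic carbon. This is the same kind of change as from compound 1 to compound 2, not the same: there the fluoro sits on a six-membered aromatic ring of carbon only, para to a large group; here it sits on such a ring that is part of a fused or bridged system of two rings, meta to a fused ring and para to a fused ring. For compound 4 the step from compound 3 is expected to be a 1.2-fold higher number from compound 3 to compound 4 (0.08 log units; within the scatter), resting on the earlier step of a 1.9-fold higher number from compound 1 to compound 2 (0.27 log units; within the scatter) lying within the scatter. Compound 4 is therefore estimated at 36 nM, between 15 nM and 90 nM.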

Compound 4, half-maximal inhibitory concentration: 10 nM
Compound 4: the middle estimate sits 3.6-fold (0.56 log units) above what was measured; the measured number lies below the stated range.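

In this assay, fluoro in place of hydrogen on an aromatic carbon gives a 3.0-fold lower number from compound 3 to compound 4 (0.48 log units; beyond the scatter), and this step does not match the earlier one on the other core: the same change on two cores in this assay, a 1.9-fold higher number (0.27 log units; within the scatter) from compound 1 to compound 2 and a 3.0-fold lower number (0.48 log units; beyond the scatter) from compound 3 to compound 4, 5.6-fold (0.75 log units) apart, beyond the scatter of two such steps. The size and direction of the step therefore do not carry from one core to the other in this series. The two pairs do not show what sets the difference, since the fluoro sits on a different ring in each pair and the cores also differ elsewhere.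

On these data alone, it remains open how a nitrile or a trifluoromethyl at the place of the fluoro in compound 4 would read. Also open, as far as these compounds go, is whether fluoro at that same place on the core of compound 1 would repeat the step seen on the core of compound 3.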